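A few compounds are considered here, and "the series" means these few. Any claim that something is new, unique, unknown or untested is made for them only; others in the source may bear on it.

In a functional assay on HT-29 cells (Homo sapiens) for antiproliferative activity, read by MTT assay, with a stated time of 72 h (on this read-out lower numbers stand for stronger inhibition and higher numbers for weaker inhibition), compound 1 `COc1cc(-c2nccn2-c2ccc(Br)cc2)cc(OC)c1OC` gives 7700 nM, compound 2 `COc1cc(-c2nccn2-c2cccc3ccccc23)cc(OC)c1OC` gives 14700 nM, and compound 3 `COc1ccc(NC(=O)c2cc(OC)c(OC)c(OC)c2)cc1[N+](=O)[O-]` gives 9700 nM. Compound 3 stands within the usual scatter of both other compounds, so its number cannot be separated from theirs. Compound 4 `COc1ccc(NC(=O)c2cc(OC)c(OC)c(OC)c2)cc1N` is compound 3 with amino in place of nitro on an aromatic carbon, ortho to a methoxy group: amino in place of nitro on an aromatic carbon. Going by the values given here, no measured pair here shows what such a swap does, so no step beyond the scatter is expected in this assay, with only a slight lean towards a lower number. The expected step, a 1.6-fold lower number from compound 3 to compound 4 (0.21 log units; within the scatter), is therefore small and uncertain. For compound 4 the estimated value is 6000 nM, with a range of 1500 nM to 20000 nM.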

Compound 4, half-maximal inhibitory concentration: 1200 nM
The estimate for compound 4 lay 5.0-fold (0.70 log units) above the measured number; the whole stated range lies above it.
By their numbers in this assay, from the lowest: compound 4; then compounds 1, 3 and 2 (each within the scatter of the next).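

Amino in place of nitro, on an aromatic carbon ortho to a methoxy group, brings an 8.1-fold lower number from compound 3 to compound 4 (0.91 log units; beyond the scatter) in this assay and so reaches beyond the usual scatter. Going by these compounds alone, this is the first pair here that differs in one place, and it shows that the group on this carbon can clearly move the number. Nothing measured here explains the step.

Going by these compounds, how a hydroxyl, an acetamide or a dimethylamino group on this same carbon would compare with amino stays open. So does whether the amino hydrogens matter at all.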